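Removing one chloro from compound 2: what to expect

A few compounds are considered here, and "the series" means these few. Any claim that something is new, unique, unknown or untested is made for them only; others in the source may bear on it.

Measured in a functional assay on MCF7 cells (Homo sapiens) for inhibition, read by sulforhodamine B assay, with a stated time of 72 h; on this read-out lower numbers stand for stronger inhibition and higher numbers for weaker inhibition:
- compound 1, `COc1ccc2cc(C(C)c3nnc4n3N=C(c3ccc(OC(F)(F)F)cc3)CS4)ccc2c1`, 8800 nM
- compound 2, `CC(c1ccc(-c2ccccc2)c(F)c1)c1nnc2n1N=C(c1ccc(Cl)cc1Cl)CS2`, 7600 nM
- compound 3, `COc1ccc2cc(C(C)c3nnc4n3N=C(c3ccc(F)cc3)CS4)ccc2c1`, 15800 nM

Compound 2 shows the lowest of the three numbers. Its nearest neighbour is compound 1, whose number is within the usual scatter of it, so the two cannot be ranked against each other; compound 3 stands beyond the scatter, with a higher number.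

Compound 4, `CC(c1ccc(-c2ccccc2)c(F)c1)c1nnc2n1N=C(c1ccc(Cl)cc1)CS2`, has not been measured. It differs from compound 2 in one place: hydrogen in place of chloro on an aromatic carbon. Cut one bond further out, the same difference reads 2,4-dichlorophenyl to 4-chlorophenyl.

Among the compounds with values here, only one measured step exists, a 1.8-fold higher number from compound 1 to compound 3 (0.25 log units; within the scatter), and it swaps one substituent for another on the ring that corresponds to the one changed here, in a different scaffold. Within the data shown here, no measured step removes a chloro or changes the 2,4-dichlorophenyl group. Because that one step is a 1.8-fold higher number from compound 1 to compound 3 (0.25 log units; within the scatter), the expectation is no step beyond the scatter in this assay, in no clear direction. The expected step is a 1.3-fold higher number from compound 2 to compound 4 (0.12 log units; within the scatter). Compound 4 is estimated at 10000 nM, between 4000 nM and 25000 nM.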

Compound 4, half-maximal inhibitory concentration: 8700 nM
Estimate against measurement, compound 4: 1.1-fold (0.06 log units) above; measured number inside the range.
By their numbers in this assay, from the lowest: compounds 2, 4, 1 and 3 (each within the scatter of the next, the first and the last beyond it).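

In this assay, the change from 2,4-dichlorophenyl to 4-chlorophenyl gives a 1.1-fold higher number from compound 2 to compound 4 (0.06 log units; within the scatter), so at this position, ortho to a large group and meta to a chloro group, hydrogen and chloro cannot be told apart on this read-out. The earlier step between compounds 1 and 3 exchanged one substituent for another elsewhere on the corresponding ring and in a different scaffold, whereas this pair tests this chloro directly, with the rest of the molecule unchanged. No supporting evidence is available to explain this result.

The compounds shown cover only chloro and hydrogen at this carbon, so they leave open whether an amine or a carboxylic acid placed there would also stay within the scatter of compound 2. They also leave open whether the remaining chloro of compound 4 can be replaced by hydrogen, and whether removing this chloro would give a similarly small step on the core of compound 1.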